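The source may report more compounds than this note shows. Statements on the series, on what has been measured and on what is new or still open speak of the compounds shown alone.

Compound 1 `CCCCN(c1nc2c(NS(C)(=O)=O)cccc2o1)[C@H](C)c1ccc(-c2ccccc2-c2nnn[nH]2)cc1`: 14 nM
Compound 2 `CCCCN(c1nc2c(NC(C)=O)cccc2o1)[C@H](C)c1ccc(-c2ccccc2-c2nnn[nH]2)cc1`: 22 nM

In a functional assay on CAL1 cells for inhibition of chemerin-like receptor 1 (Homo sapiens), with a stated time of 45 min (on this read-out lower numbers stand for stronger inhibition and higher numbers for weaker inhibition), compound 2 and compound 1 lie within the usual scatter of each other, as the step of a 1.6-fold higher number from compound 1 to compound 2 (0.20 log units; within the scatter) shows. Compound 3 `CCCCN(c1nc2c(C(=O)N(C)C)cccc2o1)[C@H](C)c1ccc(-c2ccccc2-c2nnn[nH]2)cc1` carries dimethylcarbamoyl in place of acetamido on an aromatic carbon. For the measured compounds named here, the one measured step, a 1.6-fold higher number from compound 1 to compound 2 (0.20 log units; within the scatter), only exchanged one cap on that nitrogen for another and kept its hydrogen; no measured step removes the hydrogen-bond donor, so that exchange is only a loose guide. A small change in this assay is expected, on the weaker side, as a 1.6-fold higher number from compound 2 to compound 3 (0.20 log units; within the scatter). Compound 3 is estimated at 35 nM, with a range from 12 nM to 110 nM.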

Compound 3, half-maximal inhibitory concentration: 13 nM
Compound 3: middle estimate off by 2.7-fold (0.43 log units), on the high side; the range from low to high includes it.
By their numbers in this assay, from the lowest: compounds 3, 1 and 2 (each within the scatter of the next).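

Dimethylcarbamoyl has 0 hydrogen-bond donors where acetamido has 1, so this change, unlike the earlier one, removes the hydrogen on the group at this aromatic carbon. Even so, this assay shows a 1.7-fold lower number from compound 2 to compound 3 (0.23 log units; within the scatter) and, against methanesulfonamido, a 1.1-fold lower number from compound 1 to compound 3 (0.03 log units; within the scatter) with both steps within the scatter, so among these compounds that donor is not needed to keep the number in this range. No measured evidence here bears on why this is so.

Still open, from the compounds shown here alone, is how an amine or a carboxylic acid at this aromatic carbon would read, and whether a plain hydrogen there would serve as well.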